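The source may report more compounds than this note shows. Statements on the series, on what has been measured and on what is new or still open speak of the compounds shown alone.

Measured in a functional assay on MDA-MB-231 cells (Homo sapiens), read by microscopy and transwell migration, with a stated time of 24 h; a lower number here means a stronger inhibitor, a higher number a weaker inhibitor:
- compound 1 `CCn1c(-c2ccc(C)cc2C)cs/c1=N\C(=O)c1ccccc1` gives 1950 nM
- compound 2 `CCCn1c(-c2ccc(C)cc2C)cs/c1=N\C(=O)c1ccccc1` gives 292 nM
- compound 3 `CCn1c(-c2ccccc2)cs/c1=N\C(=O)c1ccccc1` gives 51.5 nM

Compound 3 has the lowest number of the three, and compound 2 is the nearest to it. Compound 4 `CCCn1c(-c2ccccc2)cs/c1=N\C(=O)c1ccccc1` differs from compound 3 by methyl in place of hydrogen on a saturated chain carbon, two bonds along the chain from an aromatic nitrogen, which reads as ethyl to propyl. The same change has been measured once, as a 6.7-fold lower number from compound 1 to compound 2 (0.82 log units; beyond the scatter). That step was taken with 2,4-dimethylphenyl on the core rather than phenyl. The swap to phenyl was itself large, at a 38-fold lower number from compound 1 to compound 3 (1.58 log units; beyond the scatter), so the earlier gain may not carry over in full. A somewhat smaller step in the same direction is therefore expected, and the expected step is a 3.7-fold lower number from compound 3 to compound 4 (0.57 log units; beyond the scatter). Compound 4 is estimated at 14 nM, within a range of 3 nM to 60 nM.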

Compound 4, half-maximal inhibitory concentration: 657 nM
Beside the measured number, compound 4's estimate is 47-fold (1.67 log units) below it; measured number above the stated range.
By their numbers in this assay, from the lowest: compound 3; then compound 2; then compound 4; then compound 1.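

Ethyl to propyl has no single direction at this position: with phenyl on the core it gives a 13-fold higher number from compound 3 to compound 4 (1.11 log units; beyond the scatter), the reverse of its effect with 2,4-dimethylphenyl on the core. The two changes therefore do not add, and the size and direction of each depend on the other. Phenyl in place of 2,4-dimethylphenyl also reverses once propyl is present, giving a 2.3-fold higher number from compound 2 to compound 4 (0.35 log units; beyond the scatter).

Going by these compounds, what remains open is whether butyl in place of propyl would follow either trend, and whether 4-methylphenyl would behave like phenyl or like 2,4-dimethylphenyl.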